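A Larger Hydroxylated Ring on the Urea Nitrogen

The compounds below may be only part of what the source reports. "The series", "measured", "known", "first", "only" and "open" are said of these compounds alone.

Compound 3 `O=C(NC1CCN(Cc2ccn(-c3ccc(C(F)(F)F)cc3)c2)CC1)N1CC[C@H](O)C1` gives 125 nM in an assay on HEK293 cells for displacement of a labelled ligand from melanin-concentrating hormone receptor 1 (Homo sapiens) (a lower number here means a stronger inhibitor, a higher number a weaker inhibitor), the highest of the three numbers measured here. Compound 1 `O=C(NC1CCN(Cc2ccn(-c3ccc(C(F)(F)F)cc3)c2)CC1)N1CCC(c2ccccc2O)CC1` gives 36 nM in this assay, and compound 2 `COc1ccc(OC2CN(C(=O)NC3CCN(Cc4ccn(-c5ccc(C(F)(F)F)cc5)c4)CC3)C2)cc1` gives 49 nM in this assay; both gaps to compound 3 lie beyond the scatter, so compound 3 stands as the weakest inhibitor of the three measured compounds. Compound 4 `O=C(NC1CCN(Cc2ccn(-c3ccc(C(F)(F)F)cc3)c2)CC1)N1CCCC(CO)C1` has not yet been measured. The change from compound 3 to compound 4 is 3-(hydroxymethyl)piperidin-1-yl in place of 3-hydroxypyrrolidin-1-yl on a carbonyl carbon. Going by the values given here, no measured pair isolates this change, so the expectation rests on the spread of the three numbers alone: the series shows that the group on the urea nitrogen can move the result beyond the scatter, but gives no direct reading for the hydroxymethyl-bearing six-membered ring. Compound 4 is expected to give 90 nM, within a range of 35 nM to 230 nM. The step from compound 3 to compound 4 is expected to be a 1.4-fold lower number from compound 3 to compound 4 (0.14 log units; within the scatter), a modest move toward a lower number that may still fall inside the scatter.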

Compound 4, half-maximal inhibitory concentration: 23 nM
Compound 4: middle estimate off by 3.9-fold (0.59 log units), on the high side; measured number below the stated range.
By their numbers in this assay, from the lowest: compounds 4, 1 and 2 (each within the scatter of the next, the first and the last beyond it); then compound 3.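

Going by these compounds alone, replacing 3-hydroxypyrrolidin-1-yl with 3-(hydroxymethyl)piperidin-1-yl on a carbonyl carbon gives a 5.4-fold lower number from compound 3 to compound 4 (0.74 log units; beyond the scatter) in this assay, the first direct reading of a change at this position, and the two groups have the same counts of hydrogen-bond donors and acceptors. The entering group contains no aromatic ring, yet compound 4 stands within the scatter of compound 1, so among these compounds an aromatic ring in this group is not needed to reach that level. The data shown offer no evidence that explains the step.

Ring size and the hydroxymethyl group change together. The step cannot be divided between them; 3-hydroxypiperidin-1-yl or 3-(hydroxymethyl)pyrrolidin-1-yl would separate the two. On these data alone, the role of the hydroxyl also stays open, as does the outcome with a methoxymethyl or aminomethyl group in its place, or with each separate stereoisomer of compound 4.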